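The source may report more compounds than this note shows. Statements on the series, on what has been measured and on what is new or still open speak of the compounds shown alone.

Compound 2 `O=[N+]([O-])c1ccccc1S(=O)(=O)N1CC(n2cnc3c(Cl)ncnc32)OCc2ccccc21` and compound 3 `O=[N+]([O-])c1ccc(S(=O)(=O)N2CC(n3cnc4c(Cl)ncnc43)OCc3ccccc32)cc1` share a core and differ only in the nitrophenyl on the sulfonyl sulfur: 4-nitrophenyl in place of 2-nitrophenyl on a sulfonyl sulfur. In a functional assay on MCF7 cells (Homo sapiens) for antiproliferative activity (a lower number here means a stronger inhibitor, a higher number a weaker inhibitor), compound 2 gives 2100 nM, and compound 3 gives 2730 nM; the step of a 1.3-fold higher number from compound 2 to compound 3 (0.11 log units; within the scatter) is within the scatter, so the two cores behave alike here.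

Compound 1 `O=c1cc[nH]c(=O)n1C1CN(S(=O)(=O)c2ccccc2[N+](=O)[O-])c2ccccc2CO1` keeps the core of compound 2 but carries a different group on the saturated ring carbon: a group of 8 heavy atoms (4 carbon, 2 nitrogen, 2 oxygen; one six-membered aromatic ring with 2 hetero atoms) in place of a group of 10 heavy atoms (5 carbon, 4 nitrogen, 1 chlorine; one five-membered aromatic ring with 2 hetero atoms, one six-membered aromatic ring with 2 hetero atoms), on a saturated ring carbon. In this assay compound 1 gives 50900 nM, and the step of a 24-fold higher number from compound 2 to compound 1 (1.38 log units; beyond the scatter) is large and beyond the scatter.

Compound 4 `O=c1cc[nH]c(=O)n1C1CN(S(=O)(=O)c2ccc([N+](=O)[O-])cc2)c2ccccc2CO1` has not yet been measured. It stands to compound 3 as compound 1 stands to compound 2: a group of 8 heavy atoms (4 carbon, 2 nitrogen, 2 oxygen; one six-membered aromatic ring with 2 hetero atoms) in place of a group of 10 heavy atoms (5 carbon, 4 nitrogen, 1 chlorine; one five-membered aromatic ring with 2 hetero atoms, one six-membered aromatic ring with 2 hetero atoms), on a saturated ring carbon. The two descriptions of the place are the same word for word, so this is the same change made on the other core. For the measured compounds named here, since the only difference between the cores, the step from compound 2 to compound 3, is within the scatter, the step from compound 3 to compound 4 is expected to resemble the one from compound 2 to compound 1 in direction and size, resting on the single earlier instance a 24-fold higher number from compound 2 to compound 1 (1.38 log units; beyond the scatter). In this assay compound 4 is therefore expected to give about 60000 nM, most likely between 20000 nM and 180000 nM, which means an estimated step of a 22-fold higher number from compound 3 to compound 4 (1.34 log units; beyond the scatter).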

Compound 4, half-maximal inhibitory concentration: 44300 nM
For compound 4 the middle estimate is 1.4-fold (0.13 log units) above the measured one; the measured number falls inside the stated range.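

In this assay, replacing the group of 10 heavy atoms on the saturated ring carbon with the group of 8 heavy atoms again raises the number by a large margin, the new step being a 16-fold higher number from compound 3 to compound 4 (1.21 log units; beyond the scatter), and it carries over from one core to the other with little change in size: the same change on two cores in this assay, a 24-fold higher number (1.38 log units; beyond the scatter) from compound 2 to compound 1 and a 16-fold higher number (1.21 log units; beyond the scatter) from compound 3 to compound 4, 1.5-fold (0.17 log units) apart, within the scatter of two such steps. The reverse comparison agrees, since the 4-nitrophenyl and 2-nitrophenyl cores also stay alike when they carry the group of 8 heavy atoms, with a 1.1-fold lower number from compound 1 to compound 4 (0.06 log units; within the scatter), so the two changes look independent of each other in these four compounds: the same change on two cores in this assay, a 1.3-fold higher number (0.11 log units; within the scatter) from compound 2 to compound 3 and a 1.1-fold lower number (0.06 log units; within the scatter) from compound 1 to compound 4, 1.5-fold (0.17 log units) apart, within the scatter of two such steps. For the compounds shown here, this rests on only two steps, on cores that differ solely in the nitrophenyl on the sulfonyl sulfur, so it does not show that the change would carry over to a more different core, and it gives no reason why the number rises.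

The compounds shown leave open which part of the group of 10 heavy atoms matters, for instance whether an amine or a methoxy group in place of the chlorine would keep the lower numbers. They also leave open whether the step holds when the nitro group on the phenyl gives way to a nitrile or a plain hydrogen.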